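The source may hold more compounds than are shown below. What is called first, only, known or untested is meant among the compounds shown, and "the series" means these compounds.

Compound 1 `CC(C1CC1)n1cc(Nc2nc(N)nc(-c3cccc(-n4ccc5cc(C6CC6)cc(F)c5c4=O)c3CO)n2)cn1`: 51%
Compound 2 `CCn1cc(Nc2nc(N)nc(-c3cccc(-n4ccc5cc(C6CC6)cc(F)c5c4=O)c3CO)n2)cc1C#N`: 59%

In an ADME assay on microsomes from liver (Homo sapiens) for metabolic stability, read by LC-MS, using NADPH, with a stated time of 30 min, tested at 1.5 uM (on this read-out higher numbers stand for a more stable compound and lower numbers for a less stable compound), compound 2 and compound 1 sit within the scatter of each other, the step being a number 8 percentage points higher from compound 1 to compound 2 (within the scatter). Compound 3 `Nc1nc(Nc2cnn(C3CC3)c2)nc(-c2cccc(-n3ccc4cc(C5CC5)cc(F)c4c3=O)c2CO)n1` differs from compound 2 by 1-cyclopropyl-1H-pyrazol-4-yl in place of 5-cyano-1-ethyl-1H-pyrrol-3-yl on a nitrogen on an aromatic ring. Going by the values given here, only that one measured step bears on this change, and it exchanged a pyrazolyl group for the cyano-pyrrolyl without moving beyond the scatter. Compound 3 is therefore expected to stay close to compound 2, because a number 8 percentage points higher from compound 1 to compound 2 (within the scatter) was small. Compound 3 is estimated at 52%, with a range from 36% to 68%. This estimate for compound 3 means a number 7 percentage points lower from compound 2 to compound 3 (within the scatter), nothing beyond the scatter.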

Compound 3, percent of the compound remaining: 79%
For compound 3 the middle estimate is 27 percentage points below the measured one; measured number outside the range, above it.
By their numbers in this assay, from the lowest: compounds 1 and 2 (each within the scatter of the next); then compound 3.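

In this assay the group on this nitrogen clearly matters: 1-cyclopropyl-1H-pyrazol-4-yl in place of 5-cyano-1-ethyl-1H-pyrrol-3-yl gives a number 20 percentage points higher from compound 2 to compound 3 (beyond the scatter) and so goes beyond what the earlier pair showed. With the pyrazolyl ring kept, cyclopropyl in place of 1-cyclopropylethyl on the aromatic nitrogen gives a number 28 percentage points higher from compound 1 to compound 3 (beyond the scatter) and shows that the ring's substituent also counts. Nothing available explains either difference.

Still open, from the compounds shown here alone, is how a methyl group, a longer chain or an amine on that aromatic nitrogen would compare with cyclopropyl.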